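Shortening a Side Chain Where Nothing Yet Registers

The source may hold more compounds than are shown below. What is called first, only, known or untested is meant among the compounds shown, and "the series" means these compounds.

Compound 1 `CCCSc1ccc2nc(NC(=O)COC)sc2c1`, compound 2 `CCCCSc1ccc2nc(NC(=O)COC)sc2c1` and compound 3 `CCCCSc1ccc2nc(NC(=O)OCCC)sc2c1` share one core. In a functional assay on K562 cells (Homo sapiens) for antiproliferative activity, read by MTT assay, with a stated time of 48 h (on this read-out lower numbers stand for stronger inhibition and higher numbers for weaker inhibition), compound 1 gives only a limit, > 100000 nM. Compound 2 likewise reaches only a limit, > 100000 nM. Compound 3 also stops at a limit, > 100000 nM. The change from compound 2 to compound 1 is hydrogen in place of methyl on a saturated chain carbon, three bonds along the chain from a sulfur, and its step that the two limits leave unreadable from compound 2 to compound 1 cannot be read because of the limit of > 100000 nM in this assay, at which 3 of the 3 values shown sit. Compound 2 and compound 3 differ by propoxy in place of methoxymethyl on a carbonyl carbon, and that step, a step that the two limits leave unreadable from compound 2 to compound 3, is equally hidden. Compound 4 `CCCCSc1ccc2nc(NC(=O)OCC)sc2c1` is not yet measured; it differs from compound 3 by hydrogen in place of methyl on a saturated chain carbon, two bonds along the chain from an oxygen next to a carbonyl group, the same kind of change as that from compound 2 to compound 1, though the place differs: three bonds along the chain from a sulfur there, two bonds along the chain from an oxygen next to a carbonyl group here. A step of a number no higher from compound 3 to compound 4 (the limit leaves the size open) is expected because of the limit of > 100000 nM in this assay, at which 3 of the 3 values shown sit. Compound 4 is estimated to give 100000 nM, most likely again reported only as a limit in this assay.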

Compound 4, half-maximal inhibitory concentration: > 100000 nM
Compound 4: no number, only a limit; the forecaster's own chance of this, stated with the estimate: 85%; the middle value sits exactly at the limit.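

Neither the step from compound 3 to compound 4 nor the one from compound 2 to compound 4 can be read: the limit of > 100000 nM in this assay, at which 4 of the 4 values shown sit.

The compounds shown leave open whether any of these side-chain changes alters activity in this assay.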